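The source may report more compounds than this note shows. Statements on the series, on what has been measured and on what is new or still open speak of the compounds shown alone.

Measured so far in a functional assay on MCF7 cells (Homo sapiens) for inhibition; on this read-out lower numbers stand for stronger inhibition and higher numbers for weaker inhibition:

- compound 1, `CCOC(=O)c1ccc(NC(=O)N2CC2C#N)cc1`: 2100 nM
- compound 2, `CCCCNC(=O)N1CC1C#N`: 6700 nM
- compound 3, `N#CC1CN1C(=O)Nc1cccc2ccccc12`: 1700 nM

Compound 1 gives the second highest of the three numbers in this assay. Its nearest neighbour is compound 3, whose value is within the scatter of that of compound 1, so no order between the two can be read from these numbers. Compound 2 stands furthest away, with a value beyond the scatter of compound 1, so compound 2 is the weaker inhibitor of that pair.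

Compound 4, `N#CC1CN1C(=O)Nc1ccc(C(F)(F)F)cc1`, has not been measured in this assay. Relative to compound 1 the change is trifluoromethyl in place of ethoxycarbonyl on an aromatic carbon. The shared core, the nitrile and the urea link are kept; only the group on the aromatic carbon changes. For the measured compounds named here, no measured pair in the set isolates this change, so its effect is not known from the data.

For compound 4 the expected step from compound 1 is a 1.2-fold higher number from compound 1 to compound 4 (0.08 log units; within the scatter), no more than the usual scatter, with no clear direction. The estimate for compound 4 in this assay is 2500 nM, with a range from 900 nM to 7000 nM.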

Compound 4, half-maximal inhibitory concentration: 1400 nM
Compound 4: middle estimate off by 1.8-fold (0.25 log units), on the high side, and the stated range covers the measured number.
By their numbers in this assay, from the lowest: compounds 4, 3 and 1 (each within the scatter of the next); then compound 2.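

In this assay, for the compounds shown here, the first pair that differs in one place shows that trifluoromethyl can replace ethoxycarbonyl on this aromatic carbon, para to a group of 8 heavy atoms, with a 1.5-fold lower number from compound 1 to compound 4 (0.18 log units; within the scatter). Ethoxycarbonyl brings 2 hydrogen-bond acceptors and trifluoromethyl brings none, yet the step stays within the scatter, so these acceptors are not shown to be needed at this position for activity in this series. Nothing available accounts for this outcome.

From the compounds shown here alone, the two groups compared here carry no charge, so it remains open whether an amine or a carboxylic acid on the same carbon would also stay within the scatter of compound 1. Going by these compounds, it is equally open whether a longer chain, such as butoxycarbonyl, would be accommodated there.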